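The source may hold more compounds than are shown below. What is called first, only, known or untested is meant among the compounds shown, and "the series" means these compounds.

The measured compounds and their values:

compound 1, `CN(C)C1CCCC1N(C=O)c1ccccc1` — in a functional assay on the whole organism for positive allosteric modulation, with Mus musculus as the target (a higher number here means that more compound is needed for the effect, a lower number that less compound is needed), compound 1 gives 40 mg/kg
compound 2, `CCCC(=O)N(c1ccccc1)C1CCCC1N(C)C` — in this assay compound 2 gives 6 mg/kg
compound 3, `CN(C)C1CCCC1N(C=O)c1ccc(Cl)c(Cl)c1` — in this assay compound 3 gives 9 mg/kg

Compound 1 and compound 2 differ in one place. The change is propyl in place of hydrogen on a carbonyl carbon and the measured step is a 6.7-fold lower number from compound 1 to compound 2 (0.82 log units; beyond the scatter). Compound 4, `CCCC(=O)N(c1ccc(Cl)c(Cl)c1)C1CCCC1N(C)C`, has not yet been measured in this assay. It stands to compound 3 as compound 2 stands to compound 1: the change is propyl in place of hydrogen on a carbonyl carbon. Compound 1 and compound 3 share a core whose difference is not broken down here, but the place of the change is worded identically in both pairs, so the change from compound 3 to compound 4 is the same one already seen. Because the earlier step was a 6.7-fold lower number from compound 1 to compound 2 (0.82 log units; beyond the scatter), a step of similar size is expected from compound 3 to compound 4, namely a 4.5-fold lower number from compound 3 to compound 4 (0.65 log units; beyond the scatter). Compound 4 is therefore estimated at 2 mg/kg in this assay, with an expected range from 0.7 mg/kg to 6 mg/kg.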

Compound 4, dose for half-maximal effect: 2 mg/kg
For compound 4 middle estimate and measured number coincide at the digits printed; low and high end bracket the measured number.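

In this assay putting propyl in place of hydrogen on the carbonyl carbon gives a 4.5-fold lower number from compound 3 to compound 4 (0.65 log units; beyond the scatter), and the change carries from the core of compound 1 to the core of compound 3 with no difference in step size that can be told apart: the same change on two cores in this assay, a 6.7-fold lower number (0.82 log units; beyond the scatter) from compound 1 to compound 2 and a 4.5-fold lower number (0.65 log units; beyond the scatter) from compound 3 to compound 4, 1.5-fold (0.17 log units) apart, within the scatter of two such steps. Among the compounds shown here, this agreement rests on only two pairs, compound 1 with compound 2 and compound 3 with compound 4, so it supports carrying the change between these two cores and says nothing about any other core. It also does not show why the change lowers the dose needed, and it gives no reason to expect the same step in any other assay.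

The compounds shown leave open whether a similar step would follow from a shorter or longer chain on the same carbonyl carbon, such as methyl or pentyl. Also open, from the compounds shown here alone, is what a branched chain such as isopropyl, or a ring such as cyclopropyl or phenyl, would do in that place.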